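This account rests on a few compounds, and the source may have more. Where it says the series, first, only, none or still open, it means among the compounds named here.

Measured compounds in a functional assay on DLD-1 cells (Homo sapiens) for antiproliferative activity, read by CellTiter-Glo, with a stated time of 72 h; a higher number here means a weaker inhibitor, a lower number a stronger inhibitor:
- compound 1, `Cc1cc(C)c(S(=O)(=O)N2CCC(C3OCC(C)CO3)CC2)c(C)c1` — > 5000 nM
- compound 2, `CC1CCN(C2CCN(S(=O)(=O)c3cn(C)c(=O)n(C)c3=O)CC2)CC1` — > 5000 nM
- compound 3, `CCc1cc(Br)ccc1S(=O)(=O)N1CCC(N2CCC(C)CC2)CC1` — 0.6 nM

The value for compound 1 is a limit of this assay, not a number. The value for compound 2 is likewise a limit. Two of the three values sit at this limit, as noted in the limit of > 5000 nM in this assay, at which 2 of the 3 values shown sit, so compound 1 cannot be placed against compound 2 beyond saying that neither gave a number. Among the measured compounds shown here, compound 3 is the one member of the set with a measured value, and it gives 0.6 nM in this assay.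

The unmeasured compound 4, `Cc1cc(C)c(S(=O)(=O)N2CCC(N3CC(C)CC(C)C3)CC2)c(C)c1`, keeps the sulfonyl-bearing aryl part of compound 1 and changes only the group on the saturated ring carbon: a group of 8 heavy atoms (7 carbon, 1 nitrogen; one six-membered non-aromatic ring with 1 hetero atom) in place of a group of 7 heavy atoms (5 carbon, 2 oxygen; one six-membered non-aromatic ring with 2 hetero atoms), on a saturated ring carbon

For the measured compounds named here, no measured pair of compounds differs in just one place, so no measured step gives the size of such a change directly. What the set does show is that compound 3, which carries a ring amine on the same ring carbon, gives 0.6 nM. Compound 1 with its dioxane ring, in contrast, gives only a limit of this assay. On that basis the step from compound 1 to compound 4 is expected to be large and toward stronger inhibition, an at least 1000-fold lower number from compound 1 to compound 4 (3.00 log units; beyond the scatter). Compound 4 is estimated at 5 nM, within a range of 0.5 nM to 60 nM.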

Compound 4, half-maximal inhibitory concentration: 17 nM
Beside the measured number, compound 4's estimate is 3.4-fold (0.53 log units) below it; low and high end bracket the measured number.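

In this assay, the group on this saturated ring carbon now has a measured effect with the sulfonyl-bearing aryl part held constant: 3,5-dimethylpiperidin-1-yl, in place of the six-membered non-aromatic ring with 2 hetero atoms, gives an at least 290-fold lower number from compound 1 to compound 4 (2.46 log units; beyond the scatter). Among the compounds shown here, compound 1 stands at a limit, so this size is a bound and not a measured gap: the limit of > 5000 nM in this assay, at which 2 of the 4 values shown sit. The earlier compounds could not show this, since compound 1, compound 2 and compound 3 all differ from one another in more than one place; the change at this one carbon is enough to take the series from a limit to a measured value.

Still open, from the compounds shown here alone, is whether the two methyl groups of 3,5-dimethylpiperidin-1-yl contribute, and how an unsubstituted piperidine, a morpholine or an open-chain amine such as dimethylamino would read on the same carbon. Compound 3 and compound 4 differ in both the aryl part and the ring amine, so the contribution of each part cannot be separated, and the effect of a bromo or ethyl group on the aryl ring of compound 4 remains untested in the compounds shown.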